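Swapping the Thiophen-2-yl Ketone of Compound 1 for Tolyl

The source may report more compounds than this note shows. Statements on the series, on what has been measured and on what is new or still open speak of the compounds shown alone.

Compound 1 `COc1cc(-c2nnc3n2NC(c2ccco2)C(C(=O)c2cccs2)S3)cc(OC)c1OC` was tested in a functional assay on PC-3 cells (Homo sapiens) for cytotoxicity, read by MTT assay, with a stated time of 48 h (a lower number here means a stronger inhibitor, a higher number a weaker inhibitor), and gave 46200 nM, the second highest of three numbers. Compound 2 `COc1cc(-c2nnc3n2NC(c2cccs2)C(C(=O)c2ccc(F)cc2)S3)cc(OC)c1OC` gives 27400 nM in this assay, within the scatter of compound 1, while compound 3 `COc1ccc(C(=O)C2Sc3nnc(-c4cc(OC)c(OC)c(OC)c4)n3NC2c2cccs2)cc1` gives 95900 nM, beyond the scatter of compound 1. Compound 4 `COc1cc(-c2nnc3n2NC(c2ccco2)C(C(=O)c2ccc(C)cc2)S3)cc(OC)c1OC` differs from compound 1 by 4-methylphenyl in place of thiophen-2-yl on a carbonyl carbon. For the measured compounds named here, the single measured step, a 3.5-fold higher number from compound 2 to compound 3 (0.54 log units; beyond the scatter), alters the ring on the carbonyl carbon and was modest; compound 1 and compound 2 differ in two places, so their values show only that two different groups on that carbonyl carbon sit within the scatter of each other. Compound 4 is therefore expected to change little, a 1.2-fold lower number from compound 1 to compound 4 (0.06 log units; within the scatter), with an estimated 40000 nM and a range from 15000 nM to 110000 nM.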

Compound 4, half-maximal inhibitory concentration: 7500 nM
For compound 4 the middle estimate is 5.3-fold (0.73 log units) above the measured one; measured number outside the range, below it.
By their numbers in this assay, from the lowest: compound 4; then compounds 2 and 1 (each within the scatter of the next); then compound 3.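

In this assay, 4-methylphenyl in place of thiophen-2-yl on the carbonyl carbon gives a 6.2-fold lower number from compound 1 to compound 4 (0.79 log units; beyond the scatter), with the rest of compound 1 unchanged. For the compounds shown here, this shows that the ring at this position can lower the number beyond the scatter, whereas the only earlier single step here, a 3.5-fold higher number from compound 2 to compound 3 (0.54 log units; beyond the scatter), raised it. No measurement at hand explains this step. The compounds shown do not separate the methyl group from the six-membered ring that carries it; an unsubstituted phenyl on this carbonyl carbon would tell the two apart.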